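The compounds below may be only part of what the source reports. "The series", "measured", "known", "first", "only" and "open" are said of these compounds alone.

Compound 1 `CCCCCNc1nc(N)c2nc(O)n(Cc3ccccc3)c2n1` in a functional assay on the whole organism for activation, with Mus musculus as the target (a higher number here means that more compound is needed for the effect, a lower number that less compound is needed), gives 0.3 mg/kg.
Compound 2 `CCCCCOc1nc(N)c2nc(O)n(Cc3ccccc3)c2n1` in this assay gives 0.3 mg/kg.
Compound 3 `CCCC[S+]([O-])c1nc(N)c2nc(O)n(Cc3ccccc3)c2n1` in this assay gives 1 mg/kg.

Compound 1 stands level with compound 2, and the two share the lowest number of the three; compound 3 sits apart, shown by a 3.3-fold higher number from compound 1 to compound 3 (0.52 log units; beyond the scatter). Compound 4 `CCCCc1nc(N)c2nc(O)n(Cc3ccccc3)c2n1` is not yet measured. It differs from compound 1 by butyl in place of pentylamino on an aromatic carbon. For the measured compounds named here, two measured steps bear on this change: no change at the digits printed from compound 1 to compound 2 (within the scatter) shows that swapping one linking atom for another left the number unchanged, while a 3.3-fold higher number from compound 1 to compound 3 (0.52 log units; beyond the scatter) shows a modest rise when the linker was changed more deeply. Going by the values given here, removing the linker altogether has no measured precedent, so the expectation is uncertain, but a step no larger than a 1.7-fold higher number from compound 1 to compound 4 (0.22 log units; within the scatter) is estimated. Compound 4 is therefore expected to give about 0.5 mg/kg, within 0.2 mg/kg to 2 mg/kg.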

Compound 4, minimum effective dose: 0.3 mg/kg
Compound 4: the middle estimate sits 1.7-fold (0.22 log units) above what was measured; the measured number falls inside the stated range.
By their numbers in this assay, from the lowest: compounds 1, 2 and 4 (each within the scatter of the next); then compound 3.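

In this assay the linking atom proves dispensable at this carbon between two ring nitrogen atoms: butyl gives no change at the digits printed from compound 1 to compound 4 (within the scatter) and no change at the digits printed from compound 2 to compound 4 (within the scatter) even though it carries no hydrogen-bond donor or acceptor. Butyl also gives a 3.3-fold lower number from compound 3 to compound 4 (0.52 log units; beyond the scatter) and so leaves the sulfur-bearing group of compound 3 as the only one standing apart. No measurement here explains why these groups read alike. From the compounds shown here alone, whether ethyl, a longer chain such as octyl, or a phenyl ring at this carbon would hold the same number remains open.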